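The source may report more compounds than this note shows. Statements on the series, on what has been measured and on what is new or still open speak of the compounds shown alone.

Compound 3 `CC1CCCN1C1CCN(c2ccc(NC(=O)NCc3cccs3)cc2)C1` gives 1.9 nM in an assay on CHO cells for displacement of a labelled ligand from histamine receptor H3 (Macaca mulatta), read by scintillation counting, with a stated time of 1 h (on this read-out higher numbers stand for weaker inhibition and lower numbers for stronger inhibition), the lowest of the three numbers recorded. Compound 1 `Cc1cc(NC(=O)NC2CCCCC2)ccc1N1CCC(N2CCCC2C)C1` gives 11.2 nM and compound 2 `CC(=O)N1CCN(C(=O)Nc2ccc(N3CCC(N4CCCC4C)C3)c(C)c2)CC1` gives 23 nM in this assay; the step of a 2.1-fold higher number from compound 1 to compound 2 (0.31 log units; beyond the scatter) concerns the carbonyl substituent and not the ring. Compound 4 `Cc1cc(NC(=O)NCc2cccs2)ccc1N1CCC(N2CCCC2C)C1` differs from compound 3 by methyl in place of hydrogen on an aromatic carbon, on an aromatic carbon of a six-membered aromatic ring of carbon only, ortho to a large group and meta to a large group. Within the data shown here, no measured pair isolates this methyl, since compounds 1 and 2 both carry it while compound 3 does not, so no step bears directly on it. A change no larger than the scatter is therefore expected, with compound 4 estimated at 2.5 nM (range 1 nM to 6 nM), a step of a 1.3-fold higher number from compound 3 to compound 4 (0.12 log units; within the scatter).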

Compound 4, inhibition constant: 8.4 nM
The estimate for compound 4 lay 3.4-fold (0.53 log units) below the measured number; the whole stated range lies below it.
By their numbers in this assay, from the lowest: compound 3; then compounds 4 and 1 (each within the scatter of the next); then compound 2.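

In this assay, methyl in place of hydrogen on this aromatic carbon, ortho to a large group and meta to a large group, can now be read alone: it gives a 4.4-fold higher number from compound 3 to compound 4 (0.65 log units; beyond the scatter). With the methyl present, (thiophen-2-yl)methyl in place of cyclohexyl on the amide-type nitrogen gives only a 1.3-fold lower number from compound 1 to compound 4 (0.12 log units; within the scatter), while ((thiophen-2-yl)methyl)amino in place of 4-acetylpiperazin-1-yl gives a 2.7-fold lower number from compound 2 to compound 4 (0.44 log units; beyond the scatter). Nothing available explains the methyl step. Going by these compounds, whether the step holds with cyclohexyl or 4-acetylpiperazin-1-yl on the carbonyl remains open, as does how fluorine or methoxy at this position would compare.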